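A few compounds are considered here, and "the series" means these few. Any claim that something is new, unique, unknown or untested is made for them only; others in the source may bear on it.

Working notes on the series. The shared core of compound 1 `CC(O)c1cccc(C(=O)N[C@@H](C)Cn2ccc(-c3ccc(C#N)c(Cl)c3)n2)c1` carries a benzamide whose ring bears a 1-hydroxyethyl group; in a functional assay on CWR22R cells (Homo sapiens) for antiproliferative activity, read by CCK-8 assay, with a stated time of 6 days (on this read-out lower numbers stand for stronger inhibition and higher numbers for weaker inhibition), compound 1 gives 20100 nM. Compound 2 `CC(O)c1ccc(C(=O)N[C@@H](C)Cn2ccc(-c3ccc(C#N)c(Cl)c3)n2)cc1` moves that group, and in this assay compound 2 gives 9050 nM, so a 2.2-fold lower number from compound 1 to compound 2 (0.35 log units; beyond the scatter). Compound 3 `C[C@@H](Cn1ccc(-c2ccc(C#N)c(Cl)c2)n1)NC(=O)c1ccccc1F` carries a 2-fluorobenzamide instead, but in this assay compound 3 gives "not determined" (no result reported), so it stands nowhere on the scale shown. Compound 4 `C[C@@H](Cn1ccc(-c2ccc(C#N)c(Cl)c2)n1)Nc1ccccc1` differs from compound 3 by phenyl in place of (2-fluorophenyl)carbonyl on an amine nitrogen. For the measured compounds named here, no measured step bears on this change; the only step, between compound 1 and compound 2, concerns a substituent on the amide ring, not the amide itself. Both measured values sit in the weak range, so compound 4 is expected to remain weak, at an estimated 20000 nM (range 5000 nM to 80000 nM), with a real chance that only a limit is reported.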

Compound 4, half-maximal inhibitory concentration: > 30000 nM
Compound 4: only a limit was reported (the forecaster's own chance of this, stated with the estimate: 35%); middle value at least 1.5-fold (0.17 log units) from the limit.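

Compound 4 gives > 30000 nM in this assay, which is a limit, and compound 3 has no number, so no step can be read between them. The compounds shown leave open how phenyl compares with (2-fluorophenyl)carbonyl on that amine nitrogen.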